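Inverting One Chain Stereocentre: Compound 2 to Compound 3

The source may hold more compounds than are shown below. What is called first, only, known or untested is meant among the compounds shown, and "the series" means these compounds.

Compound 1 `O=C(O)[C@@H](CO)NC(=O)[C@H]1C[C@@H](O)CN1`: > 12 h
Compound 2 `O=C(N[C@H](CO)C(=O)O)[C@@H]1C[C@H](O)CN1`: > 12 h

In an ADME assay on liver (Mus musculus, strain C57BL/6) for metabolic stability, read by HPLC, with a stated time of 12 h (on this read-out lower numbers stand for a shorter-lived compound and higher numbers for a longer-lived compound), compound 2 gives > 12 h, which is a limit of the assay and not a number. Compound 1 gives > 12 h, also a limit. Compound 3 `O=C(O)[C@H](CO)NC(=O)[C@@H]1C[C@H](O)CN1` departs from compound 2 as follows: the two compounds have the same atoms and bonds and differ only in configuration as drawn: 1 of 3 stereo elements differ; a stereocentre at a saturated chain carbon is drawn R in compound 2 and S in compound 3. For the measured compounds named here, the only guide is a step that the two limits leave unreadable from compound 1 to compound 2, which bears on this change through (the fact that compounds 1 and 2 differ only in the configuration as drawn). With no readable size to carry over, no step beyond the scatter is expected in this assay. The expected outcome is a step that the limit leaves unreadable from compound 2 to compound 3. Compound 3 is estimated at 14 h, with an expected range from 9 h to 24 h.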

Compound 3, half-life: 0.51 h
Compound 3: the middle estimate sits 27-fold (1.44 log units) above what was measured; the measured number lies below the stated range.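

In this assay, inverting the single stereocentre at the saturated chain carbon gives an at least 23-fold lower number from compound 2 to compound 3 (1.37 log units; beyond the scatter). The mirror-image pair shows a step of similar reach, an at least 23-fold lower number from compound 1 to compound 3 (1.37 log units; beyond the scatter), so the earlier limits had concealed how much configuration can matter here. The change behind the first step is one of configuration alone: the fact that compounds 2 and 3 differ only in the configuration as drawn

As far as these compounds go, the step between the two compounds at the limit cannot be read, so the part played by the stereocentres at the saturated ring carbons stays open. From the compounds shown here alone, whether a methyl ester in place of the carboxylic acid would show the same dependence on the chain stereocentre also stays open.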